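A few compounds are considered here, and "the series" means these few. Any claim that something is new, unique, unknown or untested is made for them only; others in the source may bear on it.

Compound 1 `COc1ccc(OCC(=O)Nc2cccc(NC(=O)c3ccc(N(C)C)cc3)c2)cc1OC`, compound 2 `CN(C)c1ccc(C(=O)Nc2cccc(NC(=O)COc3ccc4occc(=O)c4c3)c2)cc1` and compound 3 `Cc1ccc(C(=O)Nc2cccc(NC(=O)COc3ccc4c(=O)ccoc4c3)c2)cc1` have been measured in an assay on isolated protein for inhibition of Rho-associated protein kinase 2 (Homo sapiens), read by scintillation counting, radiometric assay and 33P incorporation, with a stated time of 40 min, in the presence of a further agent that is not named here; a higher number here means a weaker inhibitor, a lower number a stronger inhibitor. Compound 1 reaches only the limit > 10000 nM. Compound 2 likewise reaches only the limit > 10000 nM. Among the compounds with values here, compound 3 gives 22 nM, the only number among the three. The step that the two limits leave unreadable from compound 1 to compound 2 therefore cannot be read, since both of its compounds sit at a limit (the limit of > 10000 nM in this assay, at which 2 of the 3 values shown sit). Compound 4 `O=C(COc1ccc2c(=O)ccoc2c1)Nc1cccc(NC(=O)c2ccc(Br)cc2)c1` has not been measured; it differs from compound 3 by bromo in place of methyl on an aromatic carbon. No measured step touches this position, so nothing shown speaks for a change beyond the scatter, and compound 4 is expected to stay close to compound 3, with a 1.4-fold higher number from compound 3 to compound 4 (0.13 log units; within the scatter). Compound 4 is estimated at 30 nM in this assay, within 8 nM to 120 nM.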

Compound 4, half-maximal inhibitory concentration: 49 nM
For compound 4 the middle estimate is 1.6-fold (0.21 log units) below the measured one; measured number inside the range.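

In this assay the position para to a large group now has its first readable step, a 2.2-fold higher number from compound 3 to compound 4 (0.35 log units; beyond the scatter) with bromo in place of methyl. The change is therefore modest but not silent, and compound 4 still gives a measured number, 49 nM and not a limit. Nothing shown accounts for this step.

As far as these compounds go, whether a fluoro, a carboxylic acid or a primary amine at this position would bring the number down or push it further up stays open. Two groups at one position set no trend.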